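The compounds below may be only part of what the source reports. "The series", "measured", "known", "first", "only" and "open" are said of these compounds alone.

Compounds measured in an ADME assay on HaCaT cells (Homo sapiens) for cytotoxicity, read by MTT assay, with a stated time of 72 h; on this read-out lower numbers stand for stronger inhibition and higher numbers for weaker inhibition:
- compound 1, `Cc1cccc(CSc2cc(Cl)c(C)cc2S(=O)(=O)/N=C(\N)N/N=C/C#Cc2ccccc2)c1`, 9000 nM
- compound 2, `Cc1cc(S(=O)(=O)/N=C(\N)N/N=C/C#Cc2ccccc2)c(SCc2ccccc2C(F)(F)F)cc1Cl`, 23000 nM
- compound 3, `Cc1cc(S(=O)(=O)/N=C(\N)N/N=C/C#Cc2ccccc2)c(SCc2ccccc2Cl)cc1Cl`, 25000 nM

All three share the same core and differ only in the group carried on a saturated chain carbon bound to a sulfur. Compound 3 sits at the upper end of the three numbers in this assay: the step of a 2.8-fold higher number from compound 1 to compound 3 (0.44 log units; beyond the scatter) is beyond the usual scatter, while the step of a 1.1-fold higher number from compound 2 to compound 3 (0.04 log units; within the scatter) is within it, so compound 2 and compound 3 cannot be told apart on these data.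

Compound 4, `Cc1cc(S(=O)(=O)/N=C(\N)N/N=C/C#Cc2ccccc2)c(SCc2ccc(Cl)cc2)cc1Cl`, is built from the same atoms as compound 3 joined differently: 4-chlorophenyl in place of 2-chlorophenyl on a saturated chain carbon bound to a sulfur. Among the measured steps, a 2.6-fold higher number from compound 1 to compound 2 (0.41 log units; beyond the scatter) and a 2.8-fold higher number from compound 1 to compound 3 (0.44 log units; beyond the scatter) show that swapping one ring for another at this position can shift the number modestly, whereas a 1.1-fold higher number from compound 2 to compound 3 (0.04 log units; within the scatter) shows that exchanging the group on that ring changes little. For the measured compounds named here, no measured pair moves a chlorine between positions on the same ring, so the new step has no direct precedent. The expected change for compound 4 in this assay is therefore small, a 1.0-fold lower number from compound 3 to compound 4 (0.02 log units; within the scatter), with no clear direction. Compound 4 is estimated at 24000 nM, within 11000 nM to 50000 nM.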

Compound 4, half-maximal inhibitory concentration: 5000 nM
Compound 4: the middle estimate sits 4.8-fold (0.68 log units) above what was measured; measured number outside the range, below it.
By their numbers in this assay, from the lowest: compounds 4 and 1 (each within the scatter of the next); then compounds 2 and 3 (each within the scatter of the next).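

In this assay, the same atoms give a 5.0-fold lower number from compound 3 to compound 4 (0.70 log units; beyond the scatter) when 4-chlorophenyl replaces 2-chlorophenyl on the saturated chain carbon bound to a sulfur, so where the chlorine sits on this ring can matter even though the group's make-up stays the same. The earlier step between compound 2 and compound 3 changed the group on the ring and stayed within the scatter, giving no sign of this sensitivity, whereas the new result also includes a 4.6-fold lower number from compound 2 to compound 4 (0.66 log units; beyond the scatter). The remaining comparison, a 1.8-fold lower number from compound 1 to compound 4 (0.26 log units; within the scatter), lies within the scatter, so compound 1 and compound 4 cannot be told apart on these data despite their different ring groups.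

No supporting data are available to explain why moving the chlorine changes the number in this assay. The compounds shown also leave open how the number would respond to a ring bearing an amine or a carboxylic acid, or to a longer chain between the sulfur and the ring.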